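This account rests on a few compounds, and the source may have more. Where it says the series, first, only, none or still open, it means among the compounds named here.

Measured in a functional assay on HL-60 cells (Homo sapiens) for inhibition, read by MTT assay, with a stated time of 72 h; a lower number here means a stronger inhibitor, a higher number a weaker inhibitor:
compound 1 `COc1cccc(N2CCN(C(=O)c3oc(C(F)(F)F)nc3-c3cccc(F)c3)CC2)c1`: "not active" (no number reported)
compound 2 `CCc1nc(-c2ccc(C(C)(C)C)cc2)c(C(=O)N2CCN(c3cccc(OC)c3)CC2)o1`: "not active" (no number reported)
compound 3 `Cc1nc(-c2ccc(F)cc2)c(C(=O)N2CCN(c3cccc(Cl)c3)CC2)o1`: 40.1 nM

Compound 1 has no single number to stand on, since in this assay compound 1 is reported only as "not active" (no number reported). Compound 2 is the one further entry of this kind, reported as "not active" (no number reported). Both carry the 3-methoxyphenyl group. Compound 3 carries a 3-chlorophenyl group instead and gives 40.1 nM, but it also differs from compound 1 elsewhere, so three compounds establish no firm pattern.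

The step now followed leads to compound 4 `O=C(c1oc(C(F)(F)F)nc1-c1cccc(F)c1)N1CCN(c2cccc(Cl)c2)CC1` and makes one change: chloro in place of methoxy on an aromatic carbon. This is chloro in place of methoxy on an aromatic carbon, 3-methoxyphenyl to 3-chlorophenyl, and the rest of compound 1 stays as it is. Among the compounds with values here, no measured pair isolates this change. A large step towards stronger inhibition in this assay is nevertheless expected, from no number to a measurable one. That expectation rests on compound 3, which shares the 3-chlorophenyl group and reads 40.1 nM. Its other differences leave a real chance that compound 4 also shows no number. For compound 4 the estimated value is 150 nM, with an expected range from 20 nM to 2000 nM.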

Compound 4, half-maximal inhibitory concentration: "not active" (no number reported)
Compound 4 has no reported number here; the estimate stays without a comparison.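

In this assay, within the data shown here, compound 4 stands at "not active" (no number reported) and compound 1 at "not active" (no number reported) as well, so no step between the two can be read. No evidence bears on this result. The compounds shown leave open which structural feature separates compound 3, the only one with a measured number, from the others.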